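This account rests on a few compounds, and the source may have more. Where it says the series, first, only, none or still open, it means among the compounds named here.

Measured so far:
compound 1 `Cc1cc(C(=O)Nc2c(F)cccc2F)nn1Cc1cc(Cl)ccc1OCc1ccccc1` — 10 nM
compound 2 `Cc1cc(C(=O)NCc2ccncc2)nn1Cc1cc(Cl)ccc1OCc1ccccc1` — 79.4 nM

Both compounds were tested in an assay on CHO-K1 cells for displacement of a labelled ligand from prostaglandin E2 receptor EP1 subtype (Homo sapiens); on this read-out higher numbers stand for weaker inhibition and lower numbers for stronger inhibition. Compound 1 gives 10 nM, and compound 2 gives 79.4 nM, the highest of the two numbers; its nearest neighbour is compound 1, and the gap is the step of a 7.9-fold higher number from compound 1 to compound 2 (0.90 log units; beyond the scatter), which is beyond the usual scatter.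

The unmeasured compound 3 `Cc1cc(NC(=O)c2c(F)cccc2F)nn1Cc1cc(Cl)ccc1OCc1ccccc1` shares the core of compound 2 and differs in one place: ((2,6-difluorophenyl)carbonyl)amino in place of ((pyridin-4-yl)methyl)carbamoyl on an aromatic carbon. This brings the 2,6-difluorophenyl ring back, though carried on the opposite side of the carbonyl compared with compound 1, so compound 1 is the nearest measured point of reference. For the measured compounds named here, the only measured step that bears on the change is a 7.9-fold higher number from compound 1 to compound 2 (0.90 log units; beyond the scatter), and it says that exchanging the 2,6-difluorophenyl for the (pyridin-4-yl)methyl cost clearly more than the scatter. Reinstating the difluorophenyl is therefore expected to lower the number in this assay, with the reversed amide leaving room for some deviation from compound 1. Compound 3 is expected to fall near 20 nM, within 5 nM to 80 nM, which amounts to an estimated step of a 4.0-fold lower number from compound 2 to compound 3 (0.60 log units; beyond the scatter).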

Compound 3, half-maximal inhibitory concentration: 12.6 nM
The estimate for compound 3 lay 1.6-fold (0.20 log units) above the measured number; the range from low to high includes it.
By their numbers in this assay, from the lowest: compounds 1 and 3 (each within the scatter of the next); then compound 2.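

In this assay, the step of a 6.3-fold lower number from compound 2 to compound 3 (0.80 log units; beyond the scatter) shows that the ((2,6-difluorophenyl)carbonyl)amino group on this aromatic carbon, next to the ring nitrogen, also gives a lower number than ((pyridin-4-yl)methyl)carbamoyl, so the earlier gain seen with the 2,6-difluorophenyl ring does not depend on a single orientation of the amide. The new information lies in the step of a 1.3-fold higher number from compound 1 to compound 3 (0.10 log units; within the scatter), which stays within the scatter: for these two compounds, exchanging (2,6-difluorophenyl)carbamoyl for ((2,6-difluorophenyl)carbonyl)amino, which reverses the amide, makes no measurable difference on this read-out. Nothing measured here explains either result, so the numbers describe what happens at this position but not why.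

Going by these compounds, whether an unsubstituted phenyl or a 2,6-dichlorophenyl could take the place of the 2,6-difluorophenyl ring and hold the number stays open. On these data alone, it is equally open how a sulfonamide in place of the amide, or a carboxylic acid on the phenyl ring, would read in this assay.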